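Compound 2 to compound 3: swap on the amide-type nitrogen

A few compounds are considered here, and "the series" means these few. Any claim that something is new, unique, unknown or untested is made for them only; others in the source may bear on it.

compound 1 `Cc1cc(C)cc(S(=O)(=O)c2c(C(=O)N[C@@H]3CCN(S(C)(=O)=O)C3)[nH]c3ccc(Cl)cc23)c1`: 24000 nM
compound 2 `Cc1cc(C)cc(S(=O)(=O)c2c(C(=O)NC3CN(Cc4n[nH]c(=O)n4C)C3)[nH]c3ccc(Cl)cc23)c1`: 25200 nM
compound 3 `Cc1cc(C)cc(S(=O)(=O)c2c(C(=O)NS(=O)(=O)C3CC3)[nH]c3ccc(Cl)cc23)c1`: not yet measured

In an ADME assay on MT4 cells (Homo sapiens) for cytotoxicity, read by MTT assay, with a stated time of 5 days (a lower number here means that less compound is tolerated, a higher number that more compound is tolerated), compound 2 gives 25200 nM, within the scatter of compound 1. From compound 2 to compound 3 the change is a group of 6 heavy atoms (3 carbon, 2 oxygen, 1 sulfur; one three-membered non-aromatic ring of carbon only) in place of a group of 12 heavy atoms (7 carbon, 4 nitrogen, 1 oxygen; one four-membered non-aromatic ring with 1 hetero atom, one five-membered aromatic ring with 3 hetero atoms), on an amide-type nitrogen. Within the data shown here, only one measured step bears on this, a 1.1-fold higher number from compound 1 to compound 2 (0.02 log units; within the scatter), a swap on the same nitrogen. Among the measured compounds shown here, no measured compound carries cyclopropylsulfonyl, so the range stays wide, and no shift beyond the scatter is expected. For compound 3 the estimated value is 25000 nM, with an expected range of 10000 nM to 60000 nM. The expected step is a 1.0-fold lower number from compound 2 to compound 3 (0.00 log units; within the scatter).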

Compound 3, half-maximal cytotoxic concentration: 147000 nM
Compound 3: middle estimate off by 5.9-fold (0.77 log units), on the low side, and the stated range ends below it.
By their numbers in this assay, from the lowest: compounds 1 and 2 (each within the scatter of the next); then compound 3.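

In this assay, the substituent on the amide-type nitrogen can move the number after all: cyclopropylsulfonyl gives a 5.8-fold higher number from compound 2 to compound 3 (0.77 log units; beyond the scatter) and a 6.1-fold higher number from compound 1 to compound 3 (0.79 log units; beyond the scatter). The earlier swap at this nitrogen, between 1-(methylsulfonyl)pyrrolidin-3-yl and the group of compound 2, stayed within the scatter, so this position is not insensitive to change. No available evidence accounts for the step.

From the compounds shown here alone, it remains open whether the step belongs to the sulfonyl or to the cyclopropyl ring. Methylsulfonyl or phenylsulfonyl on the same nitrogen would separate the two.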